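The compounds below may be only part of what the source reports. "The series", "measured", "known", "first", "only" and "open" are said of these compounds alone.

Working notes on the series. Compound 1 `O=C1C2CCCN2C(=O)N1CN1CCN(c2cccc(Cl)c2)CC1` and compound 2 `O=C1C2CCCN2C(=O)N1CN1CCN(c2cccc(C(F)(F)F)c2)CC1` share one core; compound 3 `O=C1C2CCCCN2C(=O)N1CCCN1CCN(c2cccc(Cl)c2)CC1` and compound 4 `O=C1C2CCCCN2C(=O)N1CCCN1CCN(c2cccc(C(F)(F)F)c2)CC1` share another, and the difference between the two cores is not broken down here. In an assay on isolated protein for binding affinity to Adrenergic receptor alpha-1 (Rattus norvegicus), read by radioligand binding (on this read-out higher numbers stand for weaker inhibition and lower numbers for stronger inhibition), compound 1 gives 292 nM. For compound 2 this assay gives only a limit, > 1000 nM, as the limit of > 1000 nM in this assay, at which 1 of the 3 values shown sits, records. The step of an at least 3.4-fold higher number from compound 1 to compound 2 (0.53 log units; beyond the scatter) is trifluoromethyl in place of chloro on an aromatic carbon. In this assay compound 3 gives 17.9 nM; set against compound 1 that is the lower of the two numbers. Compound 4 stands to compound 3 as compound 2 stands to compound 1: the change is trifluoromethyl in place of chloro on an aromatic carbon, the same change at the same place. The expectation for compound 4 rests on the step from compound 1 to compound 2 on the other core, and because the limit of > 1000 nM in this assay, at which 1 of the 3 values shown sits, sets only a floor to that step, its full size is not known. Compound 4 is expected to give 80 nM in this assay, between 30 nM and 300 nM. The estimated step of a 4.5-fold higher number from compound 3 to compound 4 (0.65 log units; beyond the scatter) is set near the floor of the earlier one, on the reading that the same change will move the number in the same direction by a similar size; a larger loss cannot be ruled out, because the limit of > 1000 nM in this assay, at which 1 of the 3 values shown sits, hides how much of the earlier step lies beyond it.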

Compound 4, inhibition constant: 90.4 nM
Beside the measured number, compound 4's estimate is 1.1-fold (0.05 log units) below it; measured number inside the range.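

On the second core the step of a 5.1-fold higher number from compound 3 to compound 4 (0.70 log units; beyond the scatter) is again trifluoromethyl in place of chloro on an aromatic carbon, and in this assay it runs the same way as on the first core, towards weaker inhibition, so on these two pairs the direction of the change carries from one core to the other: the same change on two cores in this assay, an at least 3.4-fold higher number (0.53 log units; beyond the scatter) from compound 1 to compound 2 and a 5.1-fold higher number (0.70 log units; beyond the scatter) from compound 3 to compound 4; the limit leaves it open whether they differ For compound 2 the value > 1000 nM is a limit of the assay and not a number. As far as these compounds go, the size of the change on the first core therefore stays unknown, so these pairs do not show that its size carries over, and two pairs on two cores make no rule for the wider series.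

The compounds shown leave open how other groups at the same place on the aromatic ring would behave, for instance a nitrile, a methoxy group or a bromo group, and whether they would follow the order seen for chloro and trifluoromethyl on both cores. They also leave open which part of the difference between the two cores matters for the size of the step, and whether the change would run the same way on a core with a longer chain.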